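Ester chain lengthening in the series

This account rests on a few compounds, and the source may have more. Where it says the series, first, only, none or still open, it means among the compounds named here.

Going by the values given here, in a functional assay on KB cells (Homo sapiens) for cytotoxicity, read by resazurin assay, with a stated time of 3 days (a lower number here means a stronger inhibitor, a higher number a weaker inhibitor), compound 2 `CCCCCCCC(=O)OCC(C)(C)CC1=C(O)C(=O)c2ccccc2C1=O` gives 38300 nM, the highest of the three numbers so far. Compound 1 `CCCCCCCCCC(=O)NCC(C)(C)CC1=C(O)C(=O)c2ccccc2C1=O` gives 18500 nM and compound 3 `CCCCCCC(C)C(=O)OCC(C)(C)CC1=C(O)C(=O)c2ccccc2C1=O` gives 16800 nM, both lower by more than the scatter. Compound 4 `CCCCCCCCCCCCCCCC(=O)OCC(C)(C)CC1=C(O)C(=O)c2ccccc2C1=O` differs from compound 2 by octyl in place of hydrogen on a saturated chain carbon, seven bonds along the chain from a carbonyl carbon. Among the compounds with values here, the only measured single-place step that bears on this is a 2.3-fold lower number from compound 2 to compound 3 (0.36 log units; beyond the scatter), which adds just a methyl to the chain. Within the data shown here, no step in chain length alone has been measured, so the guide is weak. In this assay, a somewhat lower number is expected, not clearly beyond the scatter. The expected change is a 1.5-fold lower number from compound 2 to compound 4 (0.19 log units; within the scatter). Compound 4 is estimated at 25000 nM, with an expected range of 9000 nM to 70000 nM.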

Compound 4, half-maximal inhibitory concentration: 27100 nM
The estimate for compound 4 lay 1.1-fold (0.04 log units) below the measured number; measured number inside the range.
By their numbers in this assay, from the lowest: compounds 3, 1, 4 and 2 (each within the scatter of the next, the first and the last beyond it).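

Going by these compounds alone, at this place, seven bonds along the chain from a carbonyl carbon, octyl in place of hydrogen gives a 1.4-fold lower number from compound 2 to compound 4 (0.15 log units; within the scatter) in this assay as the first step in chain length alone. Even this large addition of carbon does not carry the number beyond the scatter, whereas the single methyl on a different chain carbon gives a 2.3-fold lower number from compound 2 to compound 3 (0.36 log units; beyond the scatter) with a step just beyond it. No evidence in hand accounts for either step. Still open, on these data alone, are a longer chain at this place and an amine or a carboxylic acid in place of octyl. Also open, as far as these compounds go, is whether methyl on the saturated chain carbon bound to the carbonyl carbon would give a similar step on the longer chain of compound 4.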